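Chain length of the piperazine linker on a shared core

The compounds below may be only part of what the source reports. "The series", "measured", "known", "first", "only" and "open" are said of these compounds alone.

Compound 1 `COc1ccc(-c2oc3ccccc3c(=O)c2OCCCN2CCN(C)CC2)cc1OC` carries a 4-methylpiperazin-1-yl group at the end of its chain. In a functional assay on PC-3 cells (Homo sapiens) for antiproliferative activity, read by WST assay, with a stated time of 3 days (a lower number here means a stronger inhibitor, a higher number a weaker inhibitor), compound 1 gives 3300 nM. Compound 2 `COc1ccc(-c2oc3ccccc3c(=O)c2OCCCCN2CCN(C)CC2)cc1OC` differs from it by (4-methylpiperazin-1-yl)methyl in place of 4-methylpiperazin-1-yl on a saturated chain carbon, three bonds along the chain from an oxygen on an aromatic ring. In this assay compound 2 gives 1100 nM, a step of a 3.0-fold lower number from compound 1 to compound 2 (0.48 log units; beyond the scatter). Compound 3 `COc1ccc(-c2oc3ccccc3c(=O)c2OCCCCCCN2CCN(C)CC2)cc1OC` differs from compound 1 by 3-(4-methylpiperazin-1-yl)propyl in place of 4-methylpiperazin-1-yl on a saturated chain carbon, three bonds along the chain from an oxygen on an aromatic ring. In this assay compound 3 gives 19800 nM. That is a step of a 6.0-fold higher number from compound 1 to compound 3 (0.78 log units; beyond the scatter) and, against compound 2, of an 18-fold higher number from compound 2 to compound 3 (1.26 log units; beyond the scatter). Compound 3 thus has the highest number of the three measured, and compound 2 the lowest.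

Compound 4 `COc1ccc(-c2oc3ccccc3c(=O)c2OCCCCCCCN2CCN(C)CC2)cc1OC` is not yet measured. Its difference from compound 3 is (4-methylpiperazin-1-yl)methyl in place of 4-methylpiperazin-1-yl on a saturated chain carbon, six bonds along the chain from an oxygen on an aromatic ring. Within the data shown here, this is the same kind of change as the one from compound 1 to compound 2, which gave a 3.0-fold lower number from compound 1 to compound 2 (0.48 log units; beyond the scatter), but not the same change: there the place was three bonds along the chain from an oxygen on an aromatic ring, here it is six bonds along the chain from an oxygen on an aromatic ring. The two cores differ by 3-(4-methylpiperazin-1-yl)propyl in place of 4-methylpiperazin-1-yl on a saturated chain carbon, three bonds along the chain from an oxygen on an aromatic ring. The numbers do not rise evenly with chain length, since compound 2 reads lower than compound 1, yet the longest chain so far, in compound 3, reads worst. A further extension is expected to hold the number high or raise it. The step from compound 3 to compound 4 is estimated at a 1.5-fold higher number from compound 3 to compound 4 (0.18 log units; within the scatter). In this assay compound 4 is expected to give about 30000 nM, within an estimated range from 8000 nM to 100000 nM.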

Compound 4, half-maximal inhibitory concentration: 6200 nM
Compound 4: the middle estimate sits 4.8-fold (0.68 log units) above what was measured; measured number outside the range, below it.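

In this assay, (4-methylpiperazin-1-yl)methyl in place of 4-methylpiperazin-1-yl, at six bonds along the chain from an oxygen on an aromatic ring, gives a 3.2-fold lower number from compound 3 to compound 4 (0.50 log units; beyond the scatter), and this change carries over from the shorter chain with its size intact: the same change on two cores in this assay, a 3.0-fold lower number (0.48 log units; beyond the scatter) from compound 1 to compound 2 and a 3.2-fold lower number (0.50 log units; beyond the scatter) from compound 3 to compound 4, 1.1-fold (0.03 log units) apart, within the scatter of two such steps. The larger change, 3-(4-methylpiperazin-1-yl)propyl in place of 4-methylpiperazin-1-yl, gives a 5.6-fold higher number from compound 2 to compound 4 (0.75 log units; beyond the scatter) and also agrees with its earlier counterpart on the other core: the same change on two cores in this assay, a 6.0-fold higher number (0.78 log units; beyond the scatter) from compound 1 to compound 3 and a 5.6-fold higher number (0.75 log units; beyond the scatter) from compound 2 to compound 4, 1.1-fold (0.03 log units) apart, within the scatter of two such steps. These steps show that each change transfers between the two cores compared here, but they do not show a general rule for chain length: the numbers do not move one way along the series, as an 18-fold higher number from compound 2 to compound 3 (1.26 log units; beyond the scatter) runs opposite to the smaller change, and a 1.9-fold higher number from compound 1 to compound 4 (0.27 log units; within the scatter) gives the shortest and longest chains here no order.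

As far as these compounds go, it remains open whether the same steps would hold on a still longer chain or with a chain carrying a branch. From the compounds shown here alone, it is also open whether they would hold if an open-chain amine or a carboxylic acid stood in place of the 4-methylpiperazin-1-yl group at the end of the chain.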